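Aryl exchange at the imine carbon: cytotoxicity notes

This account rests on a few compounds, and the source may have more. Where it says the series, first, only, none or still open, it means among the compounds named here.

Compound 1 `COc1ccccc1-c1nnc(-c2ccc(C(=O)N/N=C/c3cc(O)ccc3O)cc2)o1` gives 100000 nM in an ADME assay on THP-1 cells (Homo sapiens) for cytotoxicity; on this read-out lower numbers stand for stronger inhibition and higher numbers for weaker inhibition. Of the two numbers shown it is the higher, but the gap to compound 2 lies within the scatter. Compound 2 `COc1ccccc1-c1nnc(-c2ccc(C(=O)N/N=C/c3ccc(Cl)cc3Cl)cc2)o1` gives 78800 nM in this assay, and the step of a 1.3-fold lower number from compound 1 to compound 2 (0.10 log units; within the scatter) is within the scatter. Compound 3 `COc1ccc(/C=N/NC(=O)c2ccc(-c3nnc(-c4ccccc4OC)o3)cc2)cc1O` is not yet measured; it differs from compound 1 by 3-hydroxy-4-methoxyphenyl in place of 2,5-dihydroxyphenyl on a carbon with a double bond to nitrogen. Within the data shown here, the one step that bears on this change, an exchange on the same carbon, was a 1.3-fold lower number from compound 1 to compound 2 (0.10 log units; within the scatter), so no shift beyond the scatter is expected. The expected step is a 1.1-fold lower number from compound 1 to compound 3 (0.05 log units; within the scatter). Compound 3 is estimated at 90000 nM, within 45000 nM to 180000 nM.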

Compound 3, half-maximal inhibitory concentration: 260000 nM
For compound 3 the middle estimate is 2.9-fold (0.46 log units) below the measured one; the whole stated range lies below it.
By their numbers in this assay, from the lowest: compounds 2 and 1 (each within the scatter of the next); then compound 3.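

The aryl group on the carbon with a double bond to nitrogen can move the number in this assay beyond the scatter: 3-hydroxy-4-methoxyphenyl gives a 2.6-fold higher number from compound 1 to compound 3 (0.41 log units; beyond the scatter) and a 3.3-fold higher number from compound 2 to compound 3 (0.52 log units; beyond the scatter) against 2,4-dichlorophenyl as the group that leaves. Among these three compounds, the position is therefore not indifferent to the aryl group, which the first exchange did not show. No measurement shown gives a reason for this shift.

Which part of 3-hydroxy-4-methoxyphenyl carries the step stays open. So does the outcome for an aryl group bearing an amine or a carboxylic acid.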